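Replacing the ring on compound 2

The source may report more compounds than this note shows. Statements on the series, on what has been measured and on what is new or still open speak of the compounds shown alone.

Among the measured compounds shown here, in a physicochemical assay for lipophilicity, using the shake flask method, in phosphate buffer, measured as octanol-water partition, with a stated time of 30 min, at pH 7.4 (a lower number here means a more polar compound, a higher number a more lipophilic compound), compound 1 (`Cn1cc(-c2cnc(NCc3c(F)ccc4c3CCO4)c3cn[nH]c(=O)c23)cn1`) gives 2.7, and compound 2 (`O=C1CCCN1c1cnc(NCc2c(F)ccc3c2CCO3)c2cn[nH]c(=O)c12`) gives the lowest number so far, 1.8. For the measured compounds named here, the only measured step, a number 0.90 log units lower from compound 1 to compound 2 (beyond the scatter), put 2-oxopyrrolidin-1-yl in place of 1-methyl-1H-pyrazol-4-yl. Compound 3 (`CC(=O)N1CCC(c2cnc(NCc3c(F)ccc4c3CCO4)c3cn[nH]c(=O)c23)CC1`) has 1-acetylpiperidin-4-yl in place of 2-oxopyrrolidin-1-yl on the same aromatic carbon: 1-acetylpiperidin-4-yl in place of 2-oxopyrrolidin-1-yl on an aromatic carbon. Unlike the step to compound 2, a number 0.90 log units lower from compound 1 to compound 2 (beyond the scatter), this swap exchanges one non-aromatic ring for another, so a smaller move is expected. In this assay nothing beyond the scatter is expected, the estimated step being a number 0.20 log units higher from compound 2 to compound 3 (within the scatter). The estimate for compound 3 is 2, within a range of 1.6 to 2.5.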

Compound 3, distribution coefficient: 2.9
Compound 3: the middle estimate sits 0.90 log units below what was measured; measured number above the stated range.
By their numbers in this assay, from the lowest: compound 2; then compounds 1 and 3 (each within the scatter of the next).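

At this aromatic carbon, a non-aromatic ring does not by itself give a low number in this assay: the step is a number 1.10 log units higher from compound 2 to compound 3 (beyond the scatter), although both groups count one hydrogen-bond acceptor and no donors. The step of a number 0.20 log units higher from compound 1 to compound 3 (within the scatter) shows that 1-acetylpiperidin-4-yl and 1-methyl-1H-pyrazol-4-yl are not told apart here. No supporting data explain why the two non-aromatic rings differ. The compounds shown do not separate ring size from the other differences between these groups, and how an amine or a carboxylic acid at this position would read remains open.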